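This account rests on a few compounds, and the source may have more. Where it says the series, first, only, none or still open, it means among the compounds named here.

Measured so far in a functional assay on CHO cells with sphingosine 1-phosphate receptor 4 (Homo sapiens) as the target, read by GTPgammaS binding; on this read-out lower numbers stand for an effect already at smaller amounts and higher numbers for an effect only at larger amounts of compound:
- compound 1 `Cc1ccccc1-c1noc(-c2ccc(C3CCCCC3)cc2)n1`: > 10000 nM, a limit of the assay rather than a number
- compound 2 `Cc1cc(CCC(=O)O)ccc1-c1noc(-c2ccc(OC(C)C)c(C(F)(F)F)c2)n1`: > 10000 nM, again a limit rather than a number

Compound 2 thus stands at the limit, where both values shown sit (the limit of > 10000 nM in this assay, at which 2 of the 2 values shown sit). Within the data shown here, no step between measured compounds is available. Compound 3 `CCOc1ccc(-c2nc(-c3ccc(CCC(=O)O)cc3C)no2)cc1C(F)(F)F` differs from compound 2 by hydrogen in place of methyl on a saturated chain carbon bound to an oxygen on an aromatic ring and a saturated chain carbon, which read one bond further out is isopropoxy to ethoxy. Among the measured compounds shown here, no measured pair shows what such a change does here, and compound 1 shares no single-point difference with either of the others. For the measured compounds named here, with no pair to lean on, no step beyond the scatter is expected in this assay. The estimate for compound 3 in this assay is 10000 nM, with a range from 4000 nM to 30000 nM. This corresponds to an expected step of a number no higher from compound 2 to compound 3 (the limit leaves the size open), and the result is most probably again reported only as a limit.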

Compound 3, half-maximal effective concentration: > 10000 nM
Compound 3: no number, only a limit; the forecaster's own chance of this, stated with the estimate: 75%; the middle value lies on the limit itself.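

Compound 2 and compound 3 are both reported only as limits in this assay, so the change from isopropoxy to ethoxy gives no readable step. The compounds shown leave open what that change does and which structures would give a measured number, since all values share one limit: the limit of > 10000 nM in this assay, at which 3 of the 3 values shown sit.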